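The source may hold more compounds than are shown below. What is called first, only, known or untested is meant among the compounds shown, and "the series" means these compounds.

Measured so far:
compound 1 `CCSc1nnc(Cc2ccc(Cl)cc2Oc2ccccc2Cl)[nH]1` — 134%
compound 2 `CCCSc1nnc(Cc2ccc(Cl)cc2Oc2ccccc2Cl)[nH]1` — 118%

In a functional assay on the whole organism (strain NMRI) with Mus musculus as the target, with a stated time of 60 min, at a dose of 5 mg/kg by the intraperitoneal route (on this read-out lower numbers stand for a weaker effect and higher numbers for a stronger effect at the one dose given), compound 2 holds the lower of the two numbers, and compound 1 the higher. Among the measured compounds shown here, the only measured step, a number 16 percentage points lower from compound 1 to compound 2 (beyond the scatter), came from putting methyl in place of hydrogen on a saturated chain carbon, two bonds along the chain from a sulfur. Compound 3 `CCCSc1nnc(Cc2ccc(Cl)cc2Oc2ccccc2F)[nH]1` differs from compound 2 by fluoro in place of chloro on an aromatic carbon. No measured step touches this part of the molecule, so nothing shown argues for a shift beyond the scatter. Compound 3 is therefore expected to give about 110%, from 85% to 135%. The expected step is a number 8 percentage points lower from compound 2 to compound 3 (within the scatter).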

Compound 3, a percentage reported as activity, at one dose (the size of the read-out at that dose, not a potency): 119%
Beside the measured number, compound 3's estimate is 9 percentage points below it, within the range that was stated.
By their numbers in this assay, from the lowest: compounds 2 and 3 (each within the scatter of the next); then compound 1.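

In this assay, the step from chloro to fluoro on this aromatic carbon is a number 1 percentage points higher from compound 2 to compound 3 (within the scatter), so the two halogens cannot be told apart at this position. Among the compounds shown here, this is the first view of this part of the molecule, as the earlier step concerned only the chain on the sulfur. Nothing available explains why the two read alike. The compounds shown leave open whether a plain hydrogen, a methoxy group, an amine or a carboxylic acid at this position would keep the read-out at this level.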